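Adding a 4-fluorophenyl group to compound 2

The source may report more compounds than this note shows. Statements on the series, on what has been measured and on what is new or still open speak of the compounds shown alone.

Values in a functional assay on MCF7 cells (Homo sapiens) for antiproliferative activity, read by MTT assay, with a stated time of 72 h; a higher number here means a weaker inhibitor, a lower number a stronger inhibitor:
Compound 1 `COc1cccc(N2C(=O)COc3ccc(-c4cnc(Cl)c(NS(=O)(=O)c5ccc(F)cc5)c4)cc32)c1`: > 40000 nM, a limit of the assay
Compound 2 `COc1ncc(-c2ccc3c(c2)NC(=O)CO3)cc1NS(=O)(=O)c1ccc(F)cc1`: 32300 nM
Compound 3 `COc1ccc(N2C(=O)COc3ccc(-c4cnc(Cl)c(NS(=O)(=O)c5ccc(F)cc5)c4)cc32)cc1`: 36000 nM

The numbers for compound 2 and compound 3 lie within the scatter of each other. The value for compound 1 is a limit. Compound 4 `COc1ncc(-c2ccc3c(c2)N(c2ccc(F)cc2)C(=O)CO3)cc1NS(=O)(=O)c1ccc(F)cc1` differs from compound 2 in one place: 4-fluorophenyl in place of hydrogen on an amide-type nitrogen in a ring. Among the compounds with values here, the only measured step, an at least 1.1-fold lower number from compound 1 to compound 3 (0.04 log units; that floor lies within the scatter), exchanges one methoxyphenyl group for another on that nitrogen and stays within the scatter. Within the data shown here, no measured step places a group on that nitrogen where hydrogen stood, so the expectation is loose. The expected change in this assay is a 1.6-fold lower number from compound 2 to compound 4 (0.21 log units; within the scatter), which is no move beyond the scatter. For compound 4 the estimated value is 20000 nM, with an expected range of 2000 nM to 40000 nM.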

Compound 4, half-maximal inhibitory concentration: > 40000 nM
Compound 4 gave a limit, no number; the forecaster's own chance of this, stated with the estimate: 25%; at least 2.0-fold (0.30 log units) between middle value and limit.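

In this assay compound 4 gives > 40000 nM, which is a limit of the assay and not a number. Within the data shown here, this is the first replacement of hydrogen on the amide-type nitrogen that can be read, and it gives an at least 1.2-fold higher number from compound 2 to compound 4 (0.09 log units; that floor lies within the scatter), so 4-fluorophenyl at this position does not lower the number. The full size of the step stays unknown, since the reading stops at a shared ceiling: the limit of > 40000 nM in this assay, at which 2 of the 4 values shown sit.

From the compounds shown here alone, whether methyl on that nitrogen, or a chain ending in an amine or a carboxylic acid, would move the number beyond the scatter remains open.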